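Chloro to Bromo on the Chalcone Aryl Ring

The source may report more compounds than this note shows. Statements on the series, on what has been measured and on what is new or still open speak of the compounds shown alone.

Two chalcones sharing a trimethoxyphenyl ketone core have been measured so far. Compound 1 `COc1cccc(/C=C/C(=O)c2c(OC)cc(OC)cc2OC)c1` gives 6% in a functional assay on Caco-2 cells (Homo sapiens), read by fluorescence and BrdU incorporation, with a stated time of 48 h, tested at 25 uM; a higher number here means a weaker effect of the compound at the concentration tested, a lower number a stronger effect. Compound 2 `COc1cc(OC)c(C(=O)/C=C/c2ccc(Cl)cc2)c(OC)c1` gives 1.5% in this assay; compound 2 thus stands at the lower of the two numbers, but the step of a number 4.5 percentage points lower from compound 1 to compound 2 (within the scatter) lies within the scatter, so the two cannot be told apart on these data.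

Compound 3 `COc1cc(OC)c(C(=O)/C=C/c2ccc(Br)cc2)c(OC)c1` has not yet been measured. It differs from compound 2 by a single exchange: bromo in place of chloro on an aromatic carbon. Cut one bond further out, the change reads 4-chlorophenyl to 4-bromophenyl.

Among the compounds with values here, no measured step exchanges one halogen for another; the only step available, from compound 1 to compound 2, swaps the whole aryl group and still stays within the scatter. From that, no step beyond the scatter is expected for compound 3 in this assay, and the expected step is a number 1.5 percentage points higher from compound 2 to compound 3 (within the scatter). Compound 3 is therefore estimated to give 3% in this assay, with a range from 0% to 12%.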

Compound 3, a percentage reported as activity, at one concentration (the size of the read-out at that concentration, not a potency): 1.9%
Compound 3: middle estimate off by 1.1 percentage points, on the high side; the range from low to high includes it.
By their numbers in this assay, from the lowest: compounds 2, 3 and 1 (each within the scatter of the next).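

In this assay, within the data shown here, bromo in place of chloro on an aromatic carbon, para to a large group, gives a number 0.4 percentage points higher from compound 2 to compound 3 (within the scatter) and is the first step in which one halogen replaces another, so compound 2 and compound 3 cannot be told apart on this read-out. Replacing 3-methoxyphenyl with 4-bromophenyl gives a number 4.1 percentage points lower from compound 1 to compound 3 (within the scatter) and, taken with a number 4.5 percentage points lower from compound 1 to compound 2 (within the scatter) for the 4-chlorophenyl group, shows that neither of these two aryl exchanges moves the number beyond the scatter. No measurement is available that bears on what lies behind these numbers.

The compounds shown leave open whether a group of another kind on this aromatic carbon, such as an amine, a carboxylic acid or a hydroxyl, would give a step beyond the scatter, or whether the smaller fluoro would also stay within it. They also leave open whether these three compounds would separate at other concentrations, as the read-out comes from a single concentration and is not a potency.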